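Naphthyl for phenyl on a pyrazoline-thiazolidinone hybrid

The source may hold more compounds than are shown below. What is called first, only, known or untested is meant among the compounds shown, and "the series" means these compounds.

Measured so far:
Compound 2 `COc1ccc(C2CC(c3ccccc3)=NN2C2=NC(=O)/C(=C3\C(=O)Nc4ccccc43)S2)cc1` gives 3350 nM
Compound 1 `O=C1N=C(N2N=C(c3ccccc3)CC2c2ccccc2O)S/C1=C1/C(=O)Nc2ccccc21` gives 4350 nM

Of the two numbers in a functional assay on cells (Cancer cell lines, Homo sapiens) for cytotoxicity, read by sulforhodamine B assay, with a stated time of 48 h (a higher number here means a weaker inhibitor of growth, a lower number a stronger inhibitor of growth), compound 2 has the lowest, and compound 1 sits within the scatter of it, the step being a 1.3-fold lower number from compound 1 to compound 2 (0.11 log units; within the scatter). Compound 3 `COc1ccc(C2CC(c3ccc4ccccc4c3)=NN2C2=NC(=O)/C(=C3\C(=O)Nc4ccccc43)S2)cc1` differs from compound 2 by naphthalen-2-yl in place of phenyl on a carbon with a double bond to nitrogen. Among the measured compounds shown here, no measured step touches this position; the only measured step concerns a different ring. The step is therefore expected to be small, without a known direction, and compound 3 is expected to give 3000 nM (range 1000 nM to 9000 nM), an expected step of a 1.1-fold lower number from compound 2 to compound 3 (0.05 log units; within the scatter).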

Compound 3, concentration for total growth inhibition: 2470 nM
Compound 3: the middle estimate sits 1.2-fold (0.08 log units) above what was measured; measured number inside the range.
By their numbers in this assay, from the lowest: compounds 3, 2 and 1 (each within the scatter of the next).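

In this assay, among the compounds shown here, a 1.4-fold lower number from compound 2 to compound 3 (0.13 log units; within the scatter) is the first measured step at this carbon with a double bond to nitrogen. Replacing phenyl with the larger naphthalen-2-yl, which brings a second aromatic ring of carbon only, therefore leaves the number within the scatter, so this position tolerates the larger group in this assay. No measurement here gives a reason for this result. Going by these compounds, whether an amine or a carboxylic acid on this ring would do the same remains open, as does whether naphthalen-2-yl behaves alike alongside the 2-hydroxyphenyl group of compound 1.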